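A few compounds are considered here, and "the series" means these few. Any claim that something is new, unique, unknown or untested is made for them only; others in the source may bear on it.

Compound 1 `CCC(=O)Nc1ccc(S(=O)(=O)Oc2ccccc2I)cc1` — 11000 nM
Compound 2 `CCCC(=O)Nc1ccc(S(=O)(=O)Oc2ccccc2I)cc1` — 9000 nM
Compound 3 `CC(C)C(=O)Nc1ccc(S(=O)(=O)Oc2ccccc2I)cc1` — 13000 nM

These three compounds share one core and differ only in the chain on the carbonyl of the amide. In a functional assay on M21 cells (Homo sapiens) for antiproliferative activity, read by sulforhodamine B assay, with a stated time of 48 h (a lower number here means a stronger inhibitor, a higher number a weaker inhibitor), compound 1 gives 11000 nM, compound 2 gives 9000 nM, and compound 3 gives 13000 nM. Compound 3 stands at the top of this narrow spread, but only by steps inside the scatter: a 1.2-fold higher number from compound 1 to compound 3 (0.07 log units; within the scatter) and a 1.4-fold higher number from compound 2 to compound 3 (0.16 log units; within the scatter). The third step, a 1.2-fold lower number from compound 1 to compound 2 (0.09 log units; within the scatter), is likewise within the scatter.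

Compound 4 `CC(C)(C)C(=O)Nc1ccc(S(=O)(=O)Oc2ccccc2I)cc1` extends the series by one more branch: methyl in place of hydrogen on a saturated chain carbon bound to a carbonyl carbon and two saturated chain carbons. Among the measured compounds shown here, the steps that bear on it are those that also add or rearrange a methyl on this chain, and none of them moved the number beyond the scatter. The expectation for compound 4 in this assay is therefore no step beyond the scatter, with a 1.1-fold higher number from compound 3 to compound 4 (0.03 log units; within the scatter) as the estimated change. Compound 4 is estimated at 14000 nM, with a range from 6000 nM to 35000 nM.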

Compound 4, half-maximal inhibitory concentration: 8300 nM
Estimate against measurement, compound 4: 1.7-fold (0.23 log units) above; the measured number falls inside the stated range.
By their numbers in this assay, from the lowest: compounds 4, 2, 1 and 3 (each within the scatter of the next).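

Putting a methyl in place of the hydrogen on the saturated chain carbon bound to a carbonyl carbon and two saturated chain carbons, which turns isopropyl into tert-butyl, leaves the number in this assay within the scatter (a 1.6-fold lower number from compound 3 to compound 4 (0.19 log units; within the scatter)) . The same holds when tert-butyl is read against the unbranched chains (a 1.1-fold lower number from compound 2 to compound 4 (0.04 log units; within the scatter)) and (a 1.3-fold lower number from compound 1 to compound 4 (0.12 log units; within the scatter)) , so even this fully branched group does not set itself apart from the other three chains on the carbonyl carbon. Adding a methyl to this chain also reads alike in the two places where it can be compared: the same change on two cores in this assay, a 1.2-fold lower number (0.09 log units; within the scatter) from compound 1 to compound 2 and a 1.6-fold lower number (0.19 log units; within the scatter) from compound 3 to compound 4, 1.3-fold (0.11 log units) apart, within the scatter of two such steps.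

As far as these compounds go, whether a longer chain such as hexyl, or an amine or a carboxylic acid on the chain, would move the number beyond the scatter stays open. From the compounds shown here alone, all four compounds also carry the shared core unchanged, so what a change there would do stays open too.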